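The source may hold more compounds than are shown below. What is called first, only, known or untested is meant among the compounds shown, and "the series" means these compounds.

Measured in a functional assay on HeLa cells (Homo sapiens) for inhibition, read by MTT assay, with a stated time of 72 h; a higher number here means a weaker inhibitor, a lower number a stronger inhibitor:
- Compound 1 `COc1cc(OC)c(OC)cc1/C=C/C(=O)c1cc(O)ccc1O`: a limit, > 150000 nM
- Compound 2 `COc1cc(OC)c(OC)cc1/C=C/C(=O)c1ccc([N+](=O)[O-])cc1`: a limit, > 150000 nM

Compound 2 gives no number in this assay, only a limit, > 150000 nM. Compound 1 shares that standing, so both measured compounds sit at the limit of > 150000 nM in this assay, at which 2 of the 2 values shown sit. Compound 3 `COc1cc(OC)c(OC)cc1/C=C/C(=O)c1ccc(Br)cc1` carries bromo in place of nitro on an aromatic carbon, para to a large group: bromo in place of nitro on an aromatic carbon. No measured step sizes this change, so only a small shift toward a stronger inhibitor is expected, and another limit remains quite possible. The expected change is an at least 1.5-fold lower number from compound 2 to compound 3 (0.17 log units; that floor lies within the scatter). For compound 3 the estimated value is 100000 nM, with an expected range of 25000 nM to 200000 nM.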

Compound 3, half-maximal inhibitory concentration: 31700 nM
Estimate against measurement, compound 3: 3.2-fold (0.50 log units) above; the measured number falls inside the stated range.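

In this assay, compound 3 is the first compound shown to give a number rather than a limit, so this place on the ring does respond to a change of group. Bromo in place of nitro gives an at least 4.7-fold lower number from compound 2 to compound 3 (0.67 log units; beyond the scatter), while 4-bromophenyl in place of 2,5-dihydroxyphenyl gives an at least 4.7-fold lower number from compound 1 to compound 3 (0.67 log units; beyond the scatter). Both steps are only minimum sizes, as compound 1 and compound 2 remain at a limit: the limit of > 150000 nM in this assay, at which 2 of the 3 values shown sit.

From the compounds shown here alone, it remains open whether chloro or an amine at this place would match bromo. Going by these compounds, it is also open whether the effect depends on bromo itself or simply on the loss of nitro.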